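Adding a Second Chloro to the Core of Compound 3

The source may report more compounds than this note shows. Statements on the series, on what has been measured and on what is new or still open speak of the compounds shown alone.

In a functional assay on SK-MEL-5 cells (Homo sapiens) for cytotoxicity, read by sulforhodamine B assay, with a stated time of 48 h (on this read-out lower numbers stand for stronger inhibition of growth and higher numbers for weaker inhibition of growth), three compounds have been measured so far:
compound 1, `ClCc1ccccc1Cn1cnc2c(Cl)ncnc21`: 1410 nM
compound 2, `ClCc1cccc(Cn2cnc3ncnc(Cl)c32)c1`: 4670 nM
compound 3, `ClCc1ccccc1Cn1cnc2ncnc(Cl)c21`: 1380 nM

Compound 3 has the lowest number of the three, yet its nearest neighbour, compound 1, sits within the scatter of it, so these two cannot be told apart on this read-out. Compound 2 stands furthest away from compound 3, with a number beyond the scatter above it, so compound 2 is the weaker of that pair in this assay.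

The next compound, compound 4, is `ClCc1ccccc1Cn1cnc2nc(Cl)nc(Cl)c21`. It differs from compound 3 in one place: chloro in place of hydrogen on an aromatic carbon. Among the measured compounds shown here, none of the measured pairs shows this change, so there is no earlier step to lean on; the expectation rests only on compound 3 itself and on the small size of the change. The step from compound 3 to compound 4 in this assay is expected to be a 1.4-fold lower number from compound 3 to compound 4 (0.14 log units; within the scatter), none beyond the scatter, with at most a slight lean toward a lower number. On that basis compound 4 is estimated at 1000 nM in this assay, within a range from 350 nM to 3500 nM.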

Compound 4, concentration for 50% growth inhibition: 740 nM
Compound 4: the middle estimate sits 1.4-fold (0.13 log units) above what was measured; the measured number falls inside the stated range.
By their numbers in this assay, from the lowest: compounds 4, 3 and 1 (each within the scatter of the next); then compound 2.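

Among the compounds shown here, this is the first view of the aromatic carbon between two ring nitrogen atoms, and in this assay chloro in place of hydrogen at that carbon gives a 1.9-fold lower number from compound 3 to compound 4 (0.27 log units; within the scatter). The step shows that this position can carry one more heavy atom, a chlorine, with no clear loss of growth inhibition, although the two compounds cannot be told apart on this read-out. No measurement shown here offers an explanation for this step, so the result stands only as an observation about one pair.

A single chloro also says little about other groups at this carbon: an amine, a methoxy group, a methyl group or a fluoro group could give a number close to these or a very different one. Going by these compounds, it also remains open whether chloro at this same position would give a similar step on the cores of compound 1 and compound 2, where the rest of the molecule differs from compound 3.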